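The source may hold more compounds than are shown below. What is called first, only, known or untested is meant among the compounds shown, and "the series" means these compounds.

Measured so far in an ADME assay on T29 cells (Homo sapiens) for cytotoxicity, read by sulforhodamine B assay, with a stated time of 3 days (a lower number here means a stronger inhibitor, a higher number a weaker inhibitor), each entry a limit of the assay:

- compound 1 `OCCc1cn(Cc2ccc(Cl)cc2)c2ccccc12`: > 31600 nM
- compound 2 `COCc1cn(Cc2ccc(Cl)cc2)c2ccccc12`: > 31600 nM
- compound 3 `CC(=O)OCc1cn(Cc2ccc(Cl)cc2)c2ccccc12`: > 31600 nM

Compound 3 stands at > 31600 nM, which is a limit and not a number. Its two companions are limits as well, so no order can be drawn among the three.

The next compound is compound 4 `COC(=O)CNCc1cn(Cc2ccc(Cl)cc2)c2ccccc12`. It differs from compound 3 as follows: ((methoxycarbonyl)methyl)amino in place of acetoxy on a saturated chain carbon bound to an aromatic carbon. In short, ((methoxycarbonyl)methyl)amino replaces acetoxy on a saturated chain carbon bound to an aromatic carbon.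

Among the measured compounds shown here, three measured steps bear on this swap: a step that the two limits leave unreadable from compound 1 to compound 2, a step that the two limits leave unreadable from compound 1 to compound 3 and a step that the two limits leave unreadable from compound 2 to compound 3. None of them has a readable size. All that compound 1, compound 2 and compound 3 show together is the limit of > 31600 nM in this assay, at which 3 of the 3 values shown sit. For the measured compounds named here, no measured compound carries an amino group in this place, so the data give no direct measure of this change.

The expectation of no readable shift rests on compound 3 with its > 31600 nM. The expected result in this assay is an at least 1.0-fold lower number from compound 3 to compound 4 (0.02 log units; that floor lies within the scatter), and any number that appears would be expected on the stronger side. For compound 4 the estimate is 30000 nM, with an expected range from 9000 nM to 60000 nM.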

Compound 4, half-maximal inhibitory concentration: 31600 nM
Compound 4: middle estimate off by 1.1-fold (0.02 log units), on the low side; measured number inside the range.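

In this assay, among the compounds shown here, compound 4 gives 31600 nM, the only plain number among the four compounds, and it comes with ((methoxycarbonyl)methyl)amino on a saturated chain carbon bound to an aromatic carbon: the swap for acetoxy gives a number no higher from compound 3 to compound 4 (the limit leaves the size open), the swap for methoxy gives a number no higher from compound 2 to compound 4 (the limit leaves the size open) and the swap for hydroxymethyl gives a number no higher from compound 1 to compound 4 (the limit leaves the size open). The other three compounds remain at a limit of the assay: the limit of > 31600 nM in this assay, at which 3 of the 4 values shown sit. For the compounds shown here, none of the steps to compound 4 can be read in size, so the swap shows only that the number is no higher, not how far it moved.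

From the compounds shown here alone, it remains open whether this number goes with the amino nitrogen or with the methoxycarbonyl end of the new group. A simple amine or a carboxylic acid in the same place would help to separate the two.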